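The source may hold more compounds than are shown below. What is called first, only, known or untested is meant among the compounds shown, and "the series" means these compounds.

Compound 2 `O=C1C=C2C=C[C@H](O)C[C@]2(c2ccccn2)O1` and compound 1 `CO[C@H]1CCN2O[C@H]3C=CC[C@@]4(OC(=O)C=C34)[C@@H]2C1` were both tested in an ADME assay on SK-OV-3 cells (Homo sapiens) for cytotoxicity, read by sulforhodamine B assay, with a stated time of 48 h; a higher number here means a weaker inhibitor, a lower number a stronger inhibitor. In this assay compound 1 reported only a limit, > 10000 nM, and not a number. Compound 2 likewise gave only a limit, > 10000 nM. Both readings sit at the limit of > 10000 nM in this assay, at which 2 of the 2 values shown sit, so compound 2 stands at the same edge as compound 1. Compound 3 `O=C1C=C2C=CCC[C@]2(c2ccccn2)O1` differs from compound 2 by hydrogen in place of hydroxy on a saturated ring carbon. Within the data shown here, no measured step of this kind exists here. The step that the limit leaves unreadable from compound 2 to compound 3 is expected to be small, not beyond the usual scatter. Compound 3 is therefore estimated at 15000 nM, between 5000 nM and 50000 nM.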

Compound 3, half-maximal inhibitory concentration: > 10000 nM
Compound 3: no number, only a limit (the forecaster's own chance of this, stated with the estimate: 85%); the middle value does not contradict the limit.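

No step can be read from compound 2 to compound 3: each gives only a limit, not a number. The compounds shown leave open whether hydrogen in place of hydroxy changes anything in this assay, where every reading is a limit: the limit of > 10000 nM in this assay, at which 3 of the 3 values shown sit.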